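Three Sulfonamides at the Limit, a Methyl Analogue Estimated

This account rests on a few compounds, and the source may have more. Where it says the series, first, only, none or still open, it means among the compounds named here.

Compound 1 `O=S(=O)(Nc1ccc2oc(-c3ccccc3)nc2c1)c1ccccc1Cl`: in an assay on isolated protein for inhibition of malate dehydrogenase, mitochondrial (Sus scrofa), with stated times of 45 min and 30 min (a higher number here means a weaker inhibitor, a lower number a stronger inhibitor), compound 1 gives > 63000 nM, which is a limit of the assay and not a number.
Compound 2 `O=S(=O)(Nc1ccc2oc(-c3ccccc3)nc2c1)c1cccc(O)c1`: in this assay compound 2 gives > 63000 nM, again a limit.
Compound 3 `O=S(=O)(Nc1ccc2oc(-c3ccccc3)nc2c1)c1ccc(Cl)c(Cl)c1`: in this assay compound 3 gives > 63000 nM, also a limit.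

Compound 3 therefore stands at the upper edge of what the assay reports, and so do its two companions (the limit of > 63000 nM in this assay, at which 3 of the 3 values shown sit). The three steps among them, a step that the two limits leave unreadable from compound 1 to compound 2, a step that the two limits leave unreadable from compound 1 to compound 3 and a step that the two limits leave unreadable from compound 2 to compound 3, cannot be read in size or direction, since each joins two limits.

The change to compound 4 `CS(=O)(=O)Nc1ccc2oc(-c3ccccc3)nc2c1` is methyl in place of 3,4-dichlorophenyl on a sulfonyl sulfur. Going by the values given here, none of the measured steps gives a readable size, so no step beyond the scatter can be predicted in this assay in either direction; the only guide is that every measured compound sits at the limit. Compound 4 is expected to give about 100000 nM, within 30000 nM to 500000 nM, most likely reported again as a limit. The estimated step that the limit leaves unreadable from compound 3 to compound 4 is thus not expected to be readable.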

Compound 4, half-maximal inhibitory concentration: > 63000 nM
Compound 4: no number, only a limit; the forecaster's own chance of this, stated with the estimate: 85%; the middle value is on the limit's open side.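

Compound 4 also gives only a limit, so the steps joining it to compound 1, compound 2 and compound 3 cannot be read in size or direction: the limit of > 63000 nM in this assay, at which 4 of the 4 values shown sit. The compounds shown leave open whether any group on the sulfonyl sulfur gives a readable value in this assay.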